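Phenyl for tert-butyl on a shared core

This account rests on a few compounds, and the source may have more. Where it says the series, first, only, none or still open, it means among the compounds named here.

Compound 1 `CSc1ccc(Cc2nn(C(C)(C)C)c(=O)c3ccccc23)cc1` was tested in a functional assay on aorta with Alpha-1D adrenergic receptor (Rattus norvegicus) as the target (a higher number here means that more compound is needed for the effect, a lower number that less compound is needed), and its result is a limit of the assay rather than a number: compound 1 gives > 100000 nM. Compound 2 `COc1ccc(Cc2nn(-c3ccccc3)c(=O)c3ccccc23)cc1OC`, which carries a phenyl on the ring nitrogen and two methoxy groups, is also at a limit, compound 2 giving > 100000 nM in this assay. So compound 1 stands at the limit together with the only other measured compound, as summed up by the limit of > 100000 nM in this assay, at which 2 of the 2 values shown sit. Compound 3 `CSc1ccc(Cc2nn(-c3ccccc3)c(=O)c3ccccc23)cc1` has not yet been measured; it differs from compound 1 by phenyl in place of tert-butyl on an aromatic nitrogen. Going by the values given here, no measured pair shows this change alone, so no measured step size exists for it. Because compound 2 also bears a phenyl on the ring nitrogen and sits at a limit, as the limit of > 100000 nM in this assay, at which 2 of the 2 values shown sit, records, the step from compound 1 to compound 3 is expected to be a step that the limit leaves unreadable from compound 1 to compound 3, none beyond the scatter. Compound 3 is estimated at 150000 nM, between 50000 nM and 500000 nM, most likely reported again only as a limit.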

Compound 3, half-maximal effective concentration: > 100000 nM
Compound 3: a limit, no number; the forecaster's own chance of this, stated with the estimate: 85%; the middle value is on the limit's open side.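

Going by these compounds alone, compound 1 and compound 3 both give only a limit of the assay, not a number, so no step between them can be read. In this assay the compounds shown leave open whether any change on the shared core would give a measurable value.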